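A Pyridinylcarbonyl Swap on the Shared Core

The compounds below may be only part of what the source reports. "The series", "measured", "known", "first", "only" and "open" are said of these compounds alone.

Compound 1 `COc1ccc(C2=NN(C(=O)c3ccc(Cl)nc3)C(c3ccc(OC)cc3)C2)cc1`: 6450 nM
Compound 2 `COc1ccc(C2=NN(C(=O)c3ccc(Cl)nc3)C(c3ccc(Br)cc3)C2)cc1`: 7130 nM
Compound 3 `COc1ccc(C2=NN(C(=O)c3cncc(Br)c3)C(c3ccc(OCc4ccccc4)cc3)C2)cc1`: 6240 nM

In a functional assay on WM 266-4 cells (Homo sapiens) for antiproliferative activity, read by MTT assay, with a stated time of 24 h (a higher number here means a weaker inhibitor of growth, a lower number a stronger inhibitor of growth), the three measured compounds sit close together. Compound 3 gives 6240 nM, and its gaps to compound 1 and to compound 2 both lie within the scatter. Compound 4 `COc1ccc(C2=NN(C(=O)c3ccc(Cl)nc3)C(c3ccc(OCc4ccccc4)cc3)C2)cc1` differs from compound 3 by 6-chloropyridin-3-yl in place of 5-bromopyridin-3-yl on a carbonyl carbon. Within the data shown here, the only measured step, a 1.1-fold higher number from compound 1 to compound 2 (0.04 log units; within the scatter), concerns the other aromatic ring and does not touch the carbonyl-bound ring, so no step bears directly on this change; compound 1, which carries the entering 6-chloropyridin-3-yl group, and compound 3, which carries the leaving group, differ elsewhere as well and show values within the scatter of each other. Compound 4 is therefore expected to give 6500 nM, between 3000 nM and 14000 nM. The expected step of a 1.0-fold higher number from compound 3 to compound 4 (0.02 log units; within the scatter) is estimated to stay within the scatter.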

Compound 4, concentration for 50% growth inhibition: 10600 nM
Estimate against measurement, compound 4: 1.6-fold (0.21 log units) below; low and high end bracket the measured number.
By their numbers in this assay, from the lowest: compounds 3, 1, 2 and 4 (each within the scatter of the next).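

The swap of 5-bromopyridin-3-yl for 6-chloropyridin-3-yl on the carbonyl carbon can now be read directly: it comes to a 1.7-fold higher number from compound 3 to compound 4 (0.23 log units; within the scatter) in this assay and does not separate the two compounds. With 6-chloropyridin-3-yl held fixed, benzyloxy in place of bromo gives a 1.5-fold higher number from compound 2 to compound 4 (0.17 log units; within the scatter) and phenyl in place of hydrogen on the chain carbon bound to the oxygen gives a 1.6-fold higher number from compound 1 to compound 4 (0.22 log units; within the scatter) as well, so these changes on the other aromatic ring do not separate the compounds either. No measurement shown here offers an explanation for these numbers.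

Open, going by these compounds, is whether an amine or a carboxylic acid on the pyridine ring, in place of the bromo or chloro, would move the number beyond the scatter.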